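The source may report more compounds than this note shows. Statements on the series, on what has been measured and on what is new or still open speak of the compounds shown alone.

In a functional assay on MCF7 cells (Homo sapiens) for antiproliferative activity, read by sulforhodamine B assay, with a stated time of 72 h (on this read-out lower numbers stand for stronger inhibition and higher numbers for weaker inhibition), compound 1 `O=C1C=CCC/C1=C\c1ccc(OC(F)(F)F)cc1` gives 1040 nM, a measured number. Compound 2 `COc1cc(/C=C2\CNC=CC2=O)cc(OC)c1OC` gives only a limit, > 25000 nM, and so stands at the limit of > 25000 nM in this assay, at which 1 of the 2 values shown sits. No number therefore exists for compound 2, and how far it lies from any other compound cannot be read from the data.

Compound 3 `COc1cc(/C=C2\CN(S(=O)(=O)c3ccc(C)cc3)C=CC2=O)cc(OC)c1OC` is compound 2 with one change, a (4-methylphenyl)sulfonyl in place of hydrogen on an amine nitrogen in a ring. Within the data shown here, no measured pair in this small set shows what such a change does, so any forecast is uncertain. Compound 1, at 1040 nM, shows only that a structure of this general kind can give a number well inside the range of this assay. A large step towards stronger inhibition, beyond the usual scatter, is nevertheless expected in this assay, and the estimated step is an at least 16-fold lower number from compound 2 to compound 3 (1.22 log units; beyond the scatter). The estimate for compound 3 is 1500 nM, with the expected range running from 200 nM to 10000 nM.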

Compound 3, half-maximal inhibitory concentration: 19200 nM
Compound 3: middle estimate off by 13-fold (1.11 log units), on the low side; the whole stated range lies below it.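

In this assay compound 3 gives 19200 nM, a measured number, so with a (4-methylphenyl)sulfonyl on the amine nitrogen in the ring this structure gives a reading inside the range of the assay. Compound 2, which carries hydrogen at that place, remains a limit and not a number, at > 25000 nM. The change can therefore be read only as an at least 1.3-fold lower number from compound 2 to compound 3 (0.11 log units; that floor lies within the scatter), and whether the real step lies beyond the scatter cannot be told, because only a floor for it exists: the limit of > 25000 nM in this assay, at which 1 of the 3 values shown sits.

The compounds shown leave open how much of any step belongs to the sulfonyl and how much to the 4-methylphenyl ring it carries, since a methanesulfonyl, an acetyl or a benzyl at the same amine nitrogen does not appear among them. They also leave open how a plain phenylsulfonyl, or a phenylsulfonyl with a methoxy or a chlorine in place of the methyl, would read at this place, so no trend can be drawn from this single change.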